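Replacing isopentyloxy with propyl on the carbonyl of compound 3

The source may report more compounds than this note shows. Statements on the series, on what has been measured and on what is new or still open speak of the compounds shown alone.

Measured compounds:
compound 1 `COC(=O)NS(=O)(=O)c1sc(CC(C)C)cc1-c1cccc(Cn2ccnc2)c1` gives 400 nM in an assay on HEK293 cells for displacement of a labelled ligand from Type-2 angiotensin II receptor (Homo sapiens), read by scintillation counting, with a stated time of 240 min; on this read-out higher numbers stand for weaker inhibition and lower numbers for stronger inhibition
compound 2 `CCC(C)OC(=O)NS(=O)(=O)c1sc(CC(C)C)cc1-c1cccc(Cn2ccnc2)c1` gives 440 nM
compound 3 `CC(C)CCOC(=O)NS(=O)(=O)c1sc(CC(C)C)cc1-c1cccc(Cn2ccnc2)c1` gives 230 nM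

Compound 3 holds the lowest of the three numbers, yet its lead is within the scatter: a 1.7-fold lower number from compound 1 to compound 3 (0.24 log units; within the scatter) and a 1.9-fold lower number from compound 2 to compound 3 (0.28 log units; within the scatter). Compound 4 `CCCC(=O)NS(=O)(=O)c1sc(CC(C)C)cc1-c1cccc(Cn2ccnc2)c1` differs from compound 3 by propyl in place of isopentyloxy on a carbonyl carbon. Among the measured compounds shown here, no measured step removes the oxygen on the carbonyl carbon; the three steps only vary the group on that oxygen, and all stay within the scatter, including a 1.1-fold higher number from compound 1 to compound 2 (0.04 log units; within the scatter). They therefore show the series is little sensitive to what sits there, but say nothing direct about the change to propyl. The expected step is a 1.5-fold higher number from compound 3 to compound 4 (0.18 log units; within the scatter), with a wide range reflecting the lack of a direct precedent. Compound 4 is estimated at 350 nM, between 100 nM and 1200 nM.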

Compound 4, inhibition constant: 300 nM
For compound 4 the middle estimate is 1.2-fold (0.07 log units) above the measured one; low and high end bracket the measured number.
By their numbers in this assay, from the lowest: compounds 3, 4, 1 and 2 (each within the scatter of the next).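

Taking the oxygen off the carbonyl carbon is a change the earlier compounds did not test, and in this assay compound 4 stays within the scatter of all three carbonyl-oxygen compounds (a 1.3-fold higher number from compound 3 to compound 4 (0.12 log units; within the scatter)) (a 1.5-fold lower number from compound 2 to compound 4 (0.17 log units; within the scatter)) (a 1.3-fold lower number from compound 1 to compound 4 (0.12 log units; within the scatter)). Among these four compounds, then, the oxygen is not needed to hold the number in this range. Nothing measured on these compounds explains this result.

Going by these compounds, whether a carbonyl carbon bearing an amine or a longer chain ending in a carboxylic acid would stay in this range remains open. So does whether any group at this place can move the number beyond the scatter.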